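The source may report more compounds than this note shows. Statements on the series, on what has been measured and on what is new or still open speak of the compounds shown alone.

Compound 1 `O=C1CSC(c2cccc(O)c2)N1CCN1CCCCC1` and compound 2 `O=C1CSC(c2ccccc2[N+](=O)[O-])N1CCN1CCCCC1` share the same core and were both examined in an ADME assay on Vero cells (Chlorocebus sabaeus) for cytotoxicity, read by neutral red uptake, tested at 1575 ug/mL; on this read-out higher numbers stand for a weaker effect at the one concentration tested and lower numbers for a stronger effect. In this assay compound 1 gives 13%, the lowest of the two numbers recorded, while compound 2 gives 24%, a number that lies beyond the scatter above compound 1. Among the compounds with values here, no step between these two has been worked out in detail, so only their two values can be compared.

The account turns to compound 3 `O=C1CSC(c2ccc(Cl)cc2)N1CCN1CCCCC1`, which has not yet been measured in this assay. It differs from compound 1 at a single position: 4-chlorophenyl in place of 3-hydroxyphenyl on a saturated ring carbon. Within the data shown here, nothing among the measured compounds shows how such a replacement affects the read-out, so the direction of the step is open. A modest shift is expected, one that may well stay within the usual scatter, as expressed by a number 7 percentage points higher from compound 1 to compound 3 (within the scatter). For compound 3 the expected value in this assay is 20%, with a range from 5% to 45%.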

Compound 3, a percentage reported as activity, at one concentration (the size of the read-out at that concentration, not a potency): 13%
Estimate against measurement, compound 3: 7 percentage points above, and the stated range covers the measured number.
By their numbers in this assay, from the lowest: compounds 1 and 3 (each within the scatter of the next); then compound 2.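

In this assay, placing 4-chlorophenyl in place of 3-hydroxyphenyl on the saturated ring carbon gives no change at the digits printed from compound 1 to compound 3 (within the scatter), the first step read at this position. It shows that the read-out at this one concentration can stay within the scatter when a group with 1 hydrogen-bond donor and 1 hydrogen-bond acceptor gives way to one with 0 hydrogen-bond donors and 0 hydrogen-bond acceptors, although the exchange alters both the ring substituent and its place on the aromatic ring. No measured finding offers an explanation for this result.

On these data alone, what remains open is whether the substituent and its place on the aromatic ring each leave the read-out unchanged or whether two separate effects happen to give the same number, a question that 4-hydroxyphenyl or 3-chlorophenyl at this carbon could address. Also open, as far as these compounds go, is whether the same tolerance would extend to an aromatic ring carrying an amine or a carboxylic acid, or to a longer alkyl chain in place of the aromatic ring.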